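2-fluoropyridin-3-yl gives way to 3-fluorophenyl

The source may hold more compounds than are shown below. What is called first, only, known or untested is meant among the compounds shown, and "the series" means these compounds.

Compound 1 `O=C(Nc1ccc(F)c(-c2nc3ncc(-c4ccc(F)c(F)c4)cc3[nH]2)c1)N1CCCC1` with 0.282 h as its half-life
Compound 2 `O=C(Nc1ccc(F)c(-c2nc3ncc(-c4cccnc4F)cc3[nH]2)c1)N1CCCC1` with > 1.5 h as a limit

In an ADME assay on microsomes from liver (Homo sapiens) for metabolic stability, read by LC-MS (a higher number here means that the compound lasts longer, a lower number that the compound disappears faster), compound 1 gives 0.282 h as its half-life. Compound 2 gives > 1.5 h as a limit of the assay, not as a number. Going by the values given here, the only measured step is an at least 5.3-fold higher number from compound 1 to compound 2 (0.72 log units; beyond the scatter) and it lies beyond the scatter, though one of its ends is a limit.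

Compound 3 `O=C(Nc1ccc(F)c(-c2nc3ncc(-c4cccc(F)c4)cc3[nH]2)c1)N1CCCC1` is still unmeasured in this assay and differs from compound 2 thus: 3-fluorophenyl in place of 2-fluoropyridin-3-yl on an aromatic carbon with 3-fluorophenyl in place of 2-fluoropyridin-3-yl on an aromatic carbon. That change gives up the ring nitrogen for a ring of carbon only, as in the 3,4-difluorophenyl of compound 1. The measured step therefore bears on it in reverse, and a fall of comparable size is expected, with compound 1 at 0.282 h as the nearest guide. Among the compounds with values here, no measured step separates 3-fluorophenyl from 3,4-difluorophenyl, so the range stays wide. The expected change is an at least 3.7-fold lower number from compound 2 to compound 3 (0.57 log units; beyond the scatter) on this estimate. For compound 3 the estimated half-life is 0.4 h with an expected range from 0.2 h to 0.9 h in this estimate.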

Compound 3, half-life: 0.185 h
Beside the measured number, compound 3's estimate is 2.2-fold (0.33 log units) above it; the whole stated range lies above it.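

In this assay, the new step, an at least 8.1-fold lower number from compound 2 to compound 3 (0.90 log units; beyond the scatter), shows that a single fluorine on a ring of carbon only does not bring back what the 2-fluoropyridin-3-yl group gave, so the earlier gain cannot be read as simply the loss of one fluorine from 3,4-difluorophenyl. The other step, a 1.5-fold lower number from compound 1 to compound 3 (0.18 log units; within the scatter), stays within the scatter: hydrogen in place of fluoro on this ring leaves the two compounds indistinguishable, and among the three compounds the one ring with a nitrogen stands apart from the two rings of carbon only, with none going against that. The full size of the step to compound 3 stays unknown, as compound 2 is held by a limit and not a number: the limit of > 1.5 h in this assay, at which 1 of the 3 values shown sits.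

Still open, on these data alone, is whether the ring nitrogen alone carries the step, since 2-fluoropyridin-3-yl and 3-fluorophenyl also differ in where the fluorine stands. A plain pyridin-3-yl ring with no fluorine, or a pyrimidine ring with a second nitrogen, would speak to that, and the compounds shown say nothing about either.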